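Methoxy in Place of Chloro on the Anilide of Compound 3

The compounds below may be only part of what the source reports. "The series", "measured", "known", "first", "only" and "open" are said of these compounds alone.

Compound 3 `O=C(CCC(=O)OCCCCCCSc1ccc([N+](=O)[O-])c2nonc12)Nc1ccccc1Cl` gives the lowest of the three numbers in a functional assay on 143B cells (Homo sapiens) for inhibition, read by MTT assay, with a stated time of 72 h (on this read-out lower numbers stand for stronger inhibition and higher numbers for weaker inhibition), at 2430 nM, though all three lie within the scatter of one another: compound 2 `O=C(CCC(=O)OCCCCCCSc1ccc([N+](=O)[O-])c2nonc12)Nc1ccccc1F` gives 3030 nM and compound 1 `O=C(CCC(=O)OCCCCCCSc1ccc([N+](=O)[O-])c2nonc12)Nc1ccccc1` gives 3850 nM in this assay. Within the data shown here, the steps that bear on the next change are those leading into compound 3, namely a 1.6-fold lower number from compound 1 to compound 3 (0.20 log units; within the scatter) and a 1.2-fold lower number from compound 2 to compound 3 (0.10 log units; within the scatter). Compound 4 `COc1ccccc1NC(=O)CCC(=O)OCCCCCCSc1ccc([N+](=O)[O-])c2nonc12` carries methoxy in place of chloro on an aromatic carbon. Among the measured compounds shown here, no measured step probes a methoxy group, and both steps at this carbon lie within the scatter, so the expected step is small, a 1.2-fold higher number from compound 3 to compound 4 (0.09 log units; within the scatter), and within the scatter. Compound 4 is therefore estimated at 3000 nM in this assay, with a range from 1500 nM to 6500 nM.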

Compound 4, half-maximal inhibitory concentration: 2120 nM
The estimate for compound 4 lay 1.4-fold (0.15 log units) above the measured number; the range from low to high includes it.
By their numbers in this assay, from the lowest: compounds 4, 3, 2 and 1 (each within the scatter of the next).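

In this assay, methoxy adds a hydrogen-bond acceptor and one more heavy atom than the chloro it replaces, yet the steps stay small: a 1.1-fold lower number from compound 3 to compound 4 (0.06 log units; within the scatter), a 1.4-fold lower number from compound 2 to compound 4 (0.16 log units; within the scatter) and a 1.8-fold lower number from compound 1 to compound 4 (0.26 log units; within the scatter). All three lie within the scatter, so hydrogen, fluoro, chloro and methoxy at this carbon show no difference beyond it. No measurement given here accounts for these numbers. Going by these compounds, whether an amine or a carboxylic acid at this carbon would give a step beyond the scatter remains open.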